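From ethyl to pentyl on the shared core

The source may report more compounds than this note shows. Statements on the series, on what has been measured and on what is new or still open speak of the compounds shown alone.

Compound 1 `O=C(Nc1ccccc1)C1CCN(C/C=C/c2ccccc2)CC1` gives 57900 nM
Compound 2 `CCc1ccc(NC(=O)C2CCN(C/C=C/c3ccccc3)CC2)cc1` gives 11600 nM
Compound 3 `CCCCc1ccc(NC(=O)C2CCN(C/C=C/c3ccccc3)CC2)cc1` gives 2570 nM

These numbers come from a functional assay on MGC-803 cells (Homo sapiens) for inhibition, read by MTT assay, with a stated time of 72 h (a lower number here means a stronger inhibitor, a higher number a weaker inhibitor), and compound 2 stands in the middle, lower than compound 1 and higher than compound 3. Compound 4 `CCCCCc1ccc(NC(=O)C2CCN(C/C=C/c3ccccc3)CC2)cc1` is still unmeasured. It lengthens the ethyl of compound 2 to pentyl (propyl in place of hydrogen on a saturated chain carbon, two bonds along the chain from an aromatic carbon). Going by the values given here, two measured steps bear on this. Ethyl in place of hydrogen gave a 5.0-fold lower number from compound 1 to compound 2 (0.70 log units; beyond the scatter) and lengthening ethyl to butyl gave a 4.5-fold lower number from compound 2 to compound 3 (0.65 log units; beyond the scatter) so both were modest but beyond the scatter. Pentyl goes past butyl, so a somewhat larger drop is expected, though nothing measured shows the trend continuing. The expected change is a 7.7-fold lower number from compound 2 to compound 4 (0.89 log units; beyond the scatter) in this assay if it does. For compound 4 the estimated value is 1500 nM with an expected range of 500 nM to 4500 nM in repeat measurements.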

Compound 4, half-maximal inhibitory concentration: 2550 nM
Beside the measured number, compound 4's estimate is 1.7-fold (0.23 log units) below it, and the stated range covers the measured number.
By their numbers in this assay, from the lowest: compounds 4 and 3 (each within the scatter of the next); then compound 2; then compound 1.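

In this assay, lengthening the chain stops paying off at this position: methyl in place of hydrogen, four bonds along the chain from an aromatic carbon, gives a 1.0-fold lower number from compound 3 to compound 4 (0.00 log units; within the scatter). Pentyl therefore gains no more over ethyl, with a 4.5-fold lower number from compound 2 to compound 4 (0.66 log units; beyond the scatter), than butyl did, and the whole step from the shared core stays at a 23-fold lower number from compound 1 to compound 4 (1.36 log units; beyond the scatter). Nothing measured here explains this levelling off. Going by these compounds, whether a longer chain such as hexyl would hold this level or lose ground remains open, as does the effect of an amine on the chain.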